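Swapping ethoxycarbonyl for dimethylamino on a propyl chain

The source may hold more compounds than are shown below. What is called first, only, known or untested is meant among the compounds shown, and "the series" means these compounds.

Measured in a functional assay on the whole organism with Mus musculus as the target; on this read-out higher numbers stand for an effect only at larger amounts of compound and lower numbers for an effect already at smaller amounts:
compound 1 `NC(=O)Cn1c(-c2ccc(Cl)cc2)nc2cccnc21`: 4.1 mg/kg
compound 2 `CCOC(=O)CCCNC(=O)Cn1c(-c2ccc(Cl)cc2)nc2cccnc21`: 100 mg/kg

Of these two, compound 2 holds the higher number, 100 mg/kg. Compound 3 `CN(C)CCCNC(=O)Cn1c(-c2ccc(Cl)cc2)nc2cccnc21` keeps the propyl chain on the amide-type nitrogen and differs at its end: dimethylamino in place of ethoxycarbonyl on a saturated chain carbon, three bonds along the chain from an amide-type nitrogen. Within the data shown here, no measured step changes this end group alone. Among the measured compounds shown here, the one step that bears on it is a 24-fold higher number from compound 1 to compound 2 (1.39 log units; beyond the scatter), a large change that put the whole 3-(ethoxycarbonyl)propyl in place of hydrogen. Ethoxycarbonyl is only part of that group, and 3-(dimethylamino)propyl retains the chain, so only part of that step is expected to be reversed. A moderate move to a lower number is therefore expected in this assay, with the estimated step being a 3.3-fold lower number from compound 2 to compound 3 (0.52 log units; beyond the scatter). For compound 3 the estimate is 30 mg/kg, with an expected range of 7 mg/kg to 120 mg/kg.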

Compound 3, dose for half-maximal effect: 64 mg/kg
The estimate for compound 3 lay 2.1-fold (0.33 log units) below the measured number; measured number inside the range.
By their numbers in this assay, from the lowest: compound 1; then compounds 3 and 2 (each within the scatter of the next).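

In this assay, dimethylamino in place of ethoxycarbonyl at this place on the chain gives a 1.6-fold lower number from compound 2 to compound 3 (0.19 log units; within the scatter) and so leaves the two end groups indistinguishable. Compound 3 also shows that the large step seen with ethoxycarbonyl does not depend on that end group, since a 16-fold higher number from compound 1 to compound 3 (1.19 log units; beyond the scatter) stands alongside a 24-fold higher number from compound 1 to compound 2 (1.39 log units; beyond the scatter) for these two propyl groups on the amide-type nitrogen. Nothing at hand explains this result.

From the compounds shown here alone, it remains open whether the chain itself carries the step, as a plain propyl or a methyl on the amide-type nitrogen could show. A shorter 2-(dimethylamino)ethyl chain, or a propyl chain ending in a carboxylic acid or a primary amine, could also show whether any end group or chain length comes closer to compound 1.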